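Ester for Alcohol on a Three-Membered Ring Scaffold

The compounds below may be only part of what the source reports. "The series", "measured", "known", "first", "only" and "open" are said of these compounds alone.

Compound 1 `COc1cc([C@@H]2C[C@]2(CO)C(=O)NCc2ccc(C)cc2)cc(OC)c1OC` and compound 2 `COc1cc([C@H]2C[C@]2(CO)C(=O)Nc2ccccc2Cl)cc(OC)c1OC` were both examined in a functional assay on A549 cells (Homo sapiens) for cytotoxicity, read by MTT assay, with a stated time of 48 h; on this read-out lower numbers stand for stronger inhibition and higher numbers for weaker inhibition; compound 1 gives 10500 nM and compound 2 gives 36700 nM. The difference between the two cores is not broken down here. Compound 3 `CCOC(=O)[C@]1(C(=O)NCc2ccc(C)cc2)C[C@H]1c1cc(OC)c(OC)c(OC)c1` carries ethoxycarbonyl in place of hydroxymethyl on a saturated ring carbon relative to compound 1, and in this assay compound 3 gives 13300 nM, so that a 1.3-fold higher number from compound 1 to compound 3 (0.10 log units; within the scatter). Compound 4 `CCOC(=O)[C@]1(C(=O)Nc2ccccc2Cl)C[C@@H]1c1cc(OC)c(OC)c(OC)c1`, still to be measured, carries the same change relative to compound 2, namely (ethoxycarbonyl in place of hydroxymethyl on a saturated ring carbon). Because a 1.3-fold higher number from compound 1 to compound 3 (0.10 log units; within the scatter) stayed within the scatter, the corresponding step is expected to be small as well, a 1.3-fold higher number from compound 2 to compound 4 (0.12 log units; within the scatter). Compound 4 is therefore estimated at 48000 nM in this assay, with an expected range from 18000 nM to 120000 nM.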

Compound 4, half-maximal inhibitory concentration: 50900 nM
Compound 4: the middle estimate sits 1.1-fold (0.03 log units) below what was measured; the range from low to high includes it.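

In this assay, ethoxycarbonyl in place of hydroxymethyl on a saturated ring carbon gives a 1.4-fold higher number from compound 2 to compound 4 (0.14 log units; within the scatter), and the change behaves alike on the two cores: the same change on two cores in this assay, a 1.3-fold higher number (0.10 log units; within the scatter) from compound 1 to compound 3 and a 1.4-fold higher number (0.14 log units; within the scatter) from compound 2 to compound 4, 1.1-fold (0.04 log units) apart, within the scatter of two such steps. In these two pairs, then, a small step seen on the core of compound 1 carries over to the core of compound 2. For the compounds shown here, this does not show that the change would stay as small on any other core, and with only two pairs, each with a step within the scatter, it does not show whether a larger step would carry over.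

The compounds shown leave open whether a carboxylic acid or an amine on that saturated ring carbon would give a similar number. They also leave open whether a longer chain on the ester would do so.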